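The source may report more compounds than this note shows. Statements on the series, on what has been measured and on what is new or still open speak of the compounds shown alone.

- compound 1 `C=C(Br)C(=O)Nc1ccc(C(=O)/C=C/c2ccc(OC)cc2OC)cc1` measured at 1500 nM
- compound 2 `COc1ccccc1/C=C/C(=O)c1ccc(N)cc1` measured at 8300 nM

In a functional assay on MOLT-4 cells (Homo sapiens) for antiproliferative activity, with a stated time of 48 h (a higher number here means a weaker inhibitor, a lower number a stronger inhibitor), compound 2 gives 8300 nM and is the weaker of the two, with a gap to compound 1 that lies beyond the scatter. Compound 3 `COc1ccc(/C=C/C(=O)c2ccc(N)cc2)c(OC)c1` differs from compound 2 in one place, with methoxy in place of hydrogen on an aromatic carbon. Among the measured compounds shown here, no measured pair tests this change, so in this assay only a small step towards a lower number is expected, within the scatter. The estimated step is a 1.4-fold lower number from compound 2 to compound 3 (0.14 log units; within the scatter) in this assay. For compound 3 the expected value is 6000 nM with an estimated range of 2000 nM to 18000 nM in this assay.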

Compound 3, half-maximal inhibitory concentration: 20000 nM
Beside the measured number, compound 3's estimate is 3.3-fold (0.52 log units) below it, outside the stated range (above it).
By their numbers in this assay, from the lowest: compound 1; then compound 2; then compound 3.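

In this assay, a methoxy group in place of hydrogen on this aromatic carbon, meta to a methoxy group and para to a large group, weakens the compound, with a 2.4-fold higher number from compound 2 to compound 3 (0.38 log units; beyond the scatter) as its step. Hydrogen in place of (1-bromoethenyl)carbonyl on the nitrogen gives a much larger loss, with a 13-fold higher number from compound 1 to compound 3 (1.12 log units; beyond the scatter) as its step. Nothing measured here gives a reason for either step.

On these data alone, whether a fluorine or a hydroxyl group on this carbon would also weaken the compound stays open. So does the effect of an acetyl group on the nitrogen.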